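The source may report more compounds than this note shows. Statements on the series, on what has been measured and on what is new or still open speak of the compounds shown alone.

For the measured compounds named here, compound 1 `CCn1c(CNc2ccccc2)nnc1SCc1nc2cc(C(=O)C(C)C)ccc2o1` is the only member of this small set with a numerical result: in an assay on isolated protein for inhibition of long-chain fatty acid transport protein 1 (Mus musculus) (on this read-out higher numbers stand for weaker inhibition and lower numbers for stronger inhibition), compound 1 gives 520 nM. Compound 2 `CCn1c(CNc2ccccc2)nnc1SCC(=O)Nc1ccc(C(=O)NC)cc1` reaches only a limit of the assay, > 10000 nM. Compound 3 `CCn1c(CNc2ccccc2)nnc1SCC(=O)Nc1ccc(OC)cc1` likewise stops at a limit, > 10000 nM. Going by the values given here, the one comparable pair, a step that the two limits leave unreadable from compound 2 to compound 3, is therefore not readable in size, since both of its ends sit at the limit of > 10000 nM in this assay, at which 2 of the 3 values shown sit. Compound 4 `CCn1c(CNc2ccccc2)nnc1SCc1nc2cc(Cl)ccc2o1` has not yet been measured; it differs from compound 1 by chloro in place of isopropylcarbonyl on an aromatic carbon. None of the measured steps touches this part of the shared core, so no measured step bears on the change, and its size cannot be read from the data shown. Compound 4 is expected to give 1500 nM in this assay, with a range from 300 nM to 8000 nM. The step of a 2.9-fold higher number from compound 1 to compound 4 (0.46 log units; beyond the scatter) is thus expected to be a modest weakening, not far beyond the usual scatter.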

Compound 4, half-maximal inhibitory concentration: 2300 nM
Estimate against measurement, compound 4: 1.5-fold (0.19 log units) below; the measured number falls inside the stated range.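

For the compounds shown here, replacing isopropylcarbonyl with chloro on this aromatic carbon gives a 4.4-fold higher number from compound 1 to compound 4 (0.65 log units; beyond the scatter) in this assay and is the first step in the set whose size can be read; the only earlier pair cannot be read. Here a single chlorine stands in for 5 heavy atoms and the hydrogen-bond acceptor of the carbonyl is gone, yet inhibition weakens without being lost, and compound 4 still gives a number rather than a limit. Nothing in the data shown explains the size of this step. As far as these compounds go, it stays open whether the carbonyl or the carbon part of isopropylcarbonyl matters more, which a plain isopropyl or an acetyl at this position would help to separate. How an amine, a carboxylic acid or a longer chain would read here is also unknown.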